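The source may report more compounds than this note shows. Statements on the series, on what has been measured and on what is new or still open speak of the compounds shown alone.

Of the compounds shown here, three of a shared core have been measured in a functional assay for inhibition of sodium/hydrogen exchanger (Oryctolagus cuniculus); on this read-out lower numbers stand for stronger inhibition and higher numbers for weaker inhibition. Compound 1 `Cc1cc(Br)c(S(C)(=O)=O)cc1C(=O)N=C(N)N` gives 12 nM, compound 2 `CCc1cc(C)c(C(=O)N=C(N)N)cc1S(C)(=O)=O` gives 4.8 nM, and compound 3 `CCCc1cc(C)c(C(=O)N=C(N)N)cc1S(C)(=O)=O` gives 5.7 nM. Among these three numbers compound 3 holds the second highest; the step of a 1.2-fold higher number from compound 2 to compound 3 (0.07 log units; within the scatter) lies within the scatter, while the step of a 2.1-fold lower number from compound 1 to compound 3 (0.32 log units; beyond the scatter) lies beyond it.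

Compound 4 `Cc1cc(-c2ccc(Cl)cc2)c(S(C)(=O)=O)cc1C(=O)N=C(N)N` arises from compound 3 through (4-chlorophenyl in place of propyl on an aromatic carbon). The measured steps that touch this position are a 2.5-fold lower number from compound 1 to compound 2 (0.40 log units; beyond the scatter) and a 2.1-fold lower number from compound 1 to compound 3 (0.32 log units; beyond the scatter), both swapping a halogen for a short chain, and a 1.2-fold higher number from compound 2 to compound 3 (0.07 log units; within the scatter), where lengthening that chain changed little. None of them introduces a ring at this position, so the direction of the present change is uncertain; the step is expected to be a 1.4-fold higher number from compound 3 to compound 4 (0.15 log units; within the scatter), with a wide range. For compound 4 the estimated value in this assay is 8 nM, expected to fall between 2.5 nM and 30 nM.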

Compound 4, half-maximal inhibitory concentration: 45 nM
Estimate against measurement, compound 4: 5.6-fold (0.75 log units) below, outside the stated range (above it).
By their numbers in this assay, from the lowest: compounds 2 and 3 (each within the scatter of the next); then compound 1; then compound 4.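

In this assay the earlier swaps among bromo, ethyl and propyl kept the numbers close, but the 4-chlorophenyl group, the only ring at this position, gives the highest number of the four, with a 7.9-fold higher number from compound 3 to compound 4 (0.90 log units; beyond the scatter) and a 9.4-fold higher number from compound 2 to compound 4 (0.97 log units; beyond the scatter) as the steps from the two chains. The ring also falls behind the bromo group, with a 3.8-fold higher number from compound 1 to compound 4 (0.57 log units; beyond the scatter) as the step, so this position does not tolerate every group placed on it, and inhibition weakens against all three smaller groups. Nothing available explains this loss.

The compounds shown leave open whether the ring itself or its chlorine accounts for the higher number, a question that a phenyl group without the chlorine could settle. On these data alone, how this position responds to an amine or a longer chain also remains unknown.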